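A chlorine added to the core of compound 1

This account rests on a few compounds, and the source may have more. Where it says the series, first, only, none or still open, it means among the compounds named here.

Of the compounds shown here, three have been measured in a functional assay on the whole organism for inhibition, with Mus musculus as the target, at a dose of 25 mg/kg by the oral route; on this read-out lower numbers stand for less inhibition and higher numbers for more inhibition at the one dose given (going by the name of the read-out). Compound 1, `Clc1ccc(N2CCN(CCCOc3ccc4c(c3)CCC4)CC2)cc1`, gives 58% and stands highest of the three. Compound 2, `Clc1cc(Cl)cc(N2CCN(CCCOc3ccc4c(c3)CCC4)CC2)c1`, gives 0%, and compound 3, `COc1ccccc1N1CCN(CCCOc2ccc3c(c2)CCC3)CC1`, gives 19%. The steps between them are large: a number 58 percentage points lower from compound 1 to compound 2 (beyond the scatter) with 3,5-dichlorophenyl in place of 4-chlorophenyl on an amine nitrogen in a ring, and a number 39 percentage points lower from compound 1 to compound 3 (beyond the scatter) with 2-methoxyphenyl in place of 4-chlorophenyl at the same place; the smaller step of a number 19 percentage points higher from compound 2 to compound 3 (beyond the scatter) follows from 2-methoxyphenyl in place of 3,5-dichlorophenyl there.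

The next compound, compound 4, `Clc1ccc(N2CCN(CCCOc3cc4c(cc3Cl)CCC4)CC2)cc1`, keeps the 4-chlorophenyl of compound 1 and alters the other end of the molecule instead: chloro in place of hydrogen on an aromatic carbon on an aromatic carbon of the fused ring system of the shared core. Among the compounds with values here, no measured step touches this part of the molecule; all three concern the group on the amine nitrogen in a ring. The data therefore give no direction for this change, and no step beyond the scatter is expected in this assay. For compound 4 the estimate is 50%, within a range of 20% to 80%, which means an expected step of a number 8 percentage points lower from compound 1 to compound 4 (within the scatter).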

Compound 4, a percentage reported as inhibition, in the whole organism at one dose (the size of the read-out at that dose, not a potency): 36%
Beside the measured number, compound 4's estimate is 14 percentage points above it; measured number inside the range.
By their numbers in this assay, from the lowest: compound 2; then compound 3; then compound 4; then compound 1.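

In this assay, within the data shown here, the far end of the molecule turns out to matter as well: the earlier steps all concerned the group on the amine nitrogen in a ring, whereas here the swap of hydrogen for chloro on an aromatic carbon of the shared core gives a number 22 percentage points lower from compound 1 to compound 4 (beyond the scatter). This modest step comes from a change of just one heavy atom, a single chlorine, placed on the six-membered aromatic ring of carbon only, ortho to a large group, so even a small addition at this position can lower the inhibition seen at the one dose given. The data offer no measurement that explains the drop, and a single percentage at one dose is not a potency.

It remains open whether this position is sensitive to chloro in particular or to any added group, as the compounds shown include no fluoro, methyl or methoxy group at this carbon. Also open, as far as these compounds go, is whether the same chlorine would lower the number when the 2-methoxyphenyl group replaces 4-chlorophenyl on the amine nitrogen in a ring.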